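The source may report more compounds than this note shows. Statements on the series, on what has been measured and on what is new or still open speak of the compounds shown alone.

Measured compounds in a functional assay for inhibition, with Homo sapiens as the target; on this read-out higher numbers stand for weaker inhibition and lower numbers for stronger inhibition:
- compound 1, `CCCc1nnc(O)n2c(C)ncc12`; in this assay compound 1 gives only a limit, > 48000 nM.
- compound 2, `CCc1nnc(O)n2c(C)nc(C)c12`; in this assay compound 2 gives only a limit, > 48000 nM.
- compound 3, `CCc1nnc(O)n2c(CC)nc(C)c12`; in this assay compound 3 gives 24000 nM.
- compound 4, `CCCc1nnc(O)n2c(C)nc(C)c12`; not yet measured.

Compound 2 stands at the limit of this assay, so no number is known for it. Two of the three values sit at that limit (the limit of > 48000 nM in this assay, at which 2 of the 3 values shown sit), and only compound 3 gives a number.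

Compound 4 differs from compound 2 by methyl in place of hydrogen on a saturated chain carbon, two bonds along the chain from an aromatic carbon. Within the data shown here, the one measured step that bears on this is an at least 2.0-fold lower number from compound 2 to compound 3 (0.30 log units; that floor lies within the scatter), and even that is only a floor lying within the scatter. The change to compound 4 is the same kind of addition, cut one bond further out; nothing in the series shows that such a move does more than the step to compound 3 did.

Compound 4 is therefore expected to remain weak, with an at least 1.0-fold lower number from compound 2 to compound 4 (0.02 log units; that floor lies within the scatter) as the expected step, not clearly beyond the scatter. The estimate for compound 4 is 45000 nM, in the range 18000 nM to 110000 nM, with a fair chance that only a limit is reported.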

Compound 4, half-maximal inhibitory concentration: > 48000 nM
Compound 4: no number, only a limit; the forecaster's own chance of this, stated with the estimate: 55%; at least 1.0-fold (0.02 log units) between middle value and limit.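

In this assay compound 4 gives only a limit, > 48000 nM. Compound 1 and compound 2 also stand at a limit, so the steps from each of them to compound 4 cannot be read. Still open, going by these compounds, is whether either methyl in place of hydrogen changes the read-out at all.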